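The compounds below may be only part of what the source reports. "The series", "measured", "known", "first", "only" and "open" are said of these compounds alone.

Working notes on the series. Compound 1 `Cc1ccc(NC(=S)NC(=O)c2ccc(OCc3ccc(C(F)(F)F)cc3)cc2)cc1-c1nc2ccccc2[nH]1` gives 10200 nM in a functional assay on MNK45 cells (Homo sapiens) for inhibition, read by MTT assay, with a stated time of 48 h; on this read-out higher numbers stand for weaker inhibition and lower numbers for stronger inhibition. Compound 2 `Cc1ccc(NC(=S)NC(=O)c2ccc(OCc3cccc(C(F)(F)F)c3)cc2)cc1-c1nc2ccccc2[nH]1` carries the change (3-(trifluoromethyl)phenyl in place of 4-(trifluoromethyl)phenyl on a saturated chain carbon bound to an oxygen on an aromatic ring); in this assay compound 2 gives 6050 nM, a step of a 1.7-fold lower number from compound 1 to compound 2 (0.23 log units; within the scatter). Compound 3 `Cc1ccc(NC(=O)NC(=O)c2ccc(OCc3ccc(C(F)(F)F)cc3)cc2)cc1-c1nc2ccccc2[nH]1` rests on a different core; how its core differs from that of compound 1 is not broken down here. In this assay compound 3 gives 16800 nM. Compound 4 `Cc1ccc(NC(=O)NC(=O)c2ccc(OCc3cccc(C(F)(F)F)c3)cc2)cc1-c1nc2ccccc2[nH]1` is not yet measured and stands to compound 3 as compound 2 stands to compound 1, through the change (3-(trifluoromethyl)phenyl in place of 4-(trifluoromethyl)phenyl on a saturated chain carbon bound to an oxygen on an aromatic ring), the same change at the same place. For compound 4 a step of a 1.6-fold lower number from compound 3 to compound 4 (0.20 log units; within the scatter) in this assay is expected, resting only on the earlier step of a 1.7-fold lower number from compound 1 to compound 2 (0.23 log units; within the scatter), which lay within the scatter, so the expectation is loose. Compound 4 is estimated at 10500 nM, with a range from 5000 nM to 22000 nM.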

Compound 4, half-maximal inhibitory concentration: 9600 nM
Beside the measured number, compound 4's estimate is 1.1-fold (0.04 log units) above it, and the stated range covers the measured number.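

In this assay the change from 4-(trifluoromethyl)phenyl to 3-(trifluoromethyl)phenyl gives a 1.8-fold lower number from compound 3 to compound 4 (0.24 log units; within the scatter) and matches the step on the other core: the same change on two cores in this assay, a 1.7-fold lower number (0.23 log units; within the scatter) from compound 1 to compound 2 and a 1.8-fold lower number (0.24 log units; within the scatter) from compound 3 to compound 4, 1.0-fold (0.02 log units) apart, within the scatter of two such steps. The change therefore carries between these two cores with no detectable difference in step size. This does not establish an effect of the change itself, as each step alone lies within the scatter, and two cores in one assay support no wider rule.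

Still open, from the compounds shown here alone, is how a third core would respond to this change. Also open, going by these compounds, is what a carboxylic acid, an amine or a longer chain would do on the saturated chain carbon bound to an oxygen on an aromatic ring.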